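Ester to ketone at the chain terminus of compound 1

The compounds below may be only part of what the source reports. "The series", "measured", "known", "first", "only" and "open" are said of these compounds alone.

Three compounds of the series have a number in a physicochemical assay for lipophilicity; a higher number here means a more lipophilic compound, a lower number a more polar compound. Compound 1 `CCCOC(=O)/C=C(C)/C=C/CC(C)CCCC(C)(C)OC` gives 6.08 in this assay and stands second highest of the three. Compound 2 `CC(/C=C/CC(C)CCCC(C)(C)C)=C\C(=O)OC(C)C` gives 7.56, a number beyond the scatter above compound 1. Compound 3 `CC(/C=C/CC(C)CCCC(C)C)=C\C(=O)N(C)C` gives 4.94, a number beyond the scatter below compound 1. No two of these compounds differ in only one place, so no single step within the measured set can be read from them; the spread from compound 3 through compound 1 to compound 2 only shows that this assay separates the series widely.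

The step under consideration leaves compound 1 for compound 4 `CCC(=O)/C=C(C)/C=C/CC(C)CCCC(C)(C)OC`. The change is:

ethyl in place of propoxy on a carbonyl carbon

The group that leaves carries one hydrogen-bond acceptor and four heavy atoms, the group that enters none and two. For the measured compounds named here, no measured pair shows what such a change does in this assay, so the expectation rests on the change alone. The step from compound 1 to compound 4 in this assay is expected to be a number 0.48 log units lower from compound 1 to compound 4 (beyond the scatter), downward and modest, near the edge of the scatter. Compound 4 is estimated at 5.6, within 5.1 to 6.1.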

Compound 4, partition coefficient: 5.07
Estimate against measurement, compound 4: 0.53 log units above; measured number outside the range, below it.
By their numbers in this assay, from the lowest: compounds 3 and 4 (each within the scatter of the next); then compound 1; then compound 2.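

In this assay, for the compounds shown here, the change from propoxycarbonyl to propanoyl gives the first step that can be read at a single place: a number 1.01 log units lower from compound 1 to compound 4 (beyond the scatter). The earlier spread across compound 1, compound 2 and compound 3 could not be assigned to any one place, since those compounds differ in more than one; this pair shows that the group on the carbonyl carbon alone can move the number by a large step, beyond the scatter, with the rest of compound 1 unchanged. No measurement in hand bears on the origin of this step.

One step cannot separate the loss of the propoxy oxygen from the shorter carbon chain on the carbonyl carbon, so a butyl group there, which keeps the chain length of propoxy without its oxygen, or a dimethylamino group, as on compound 3, would each read differently on the core of compound 1. As far as these compounds go, whether the same step holds for ethyl in place of an ester group on the cores of compound 2 and compound 3 also remains open.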